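A Hydroxyphenyl Swap on the Triazole-Linked Series

A few compounds are considered here, and "the series" means these few. Any claim that something is new, unique, unknown or untested is made for them only; others in the source may bear on it.

Measured so far in a functional assay on HepG2 cells (Homo sapiens) for inhibition, read by MTT assay, with a stated time of 24 h; a higher number here means a weaker inhibitor, a lower number a stronger inhibitor:
- compound 1 `CC1(C)[C@H]2CC[C@]1(C)N(Cc1cn(-c3cccc(C#N)c3)nn1)C(=O)C2` gives 40 nM
- compound 2 `CC1(C)[C@H]2CC[C@]1(C)N(Cc1cn(-c3ccc(Br)cc3)nn1)C(=O)C2` gives 110 nM

Of these two, compound 2 carries the higher number, at 110 nM, and so it is the weaker inhibitor of the pair. The next compound to be tested is compound 3 `CC1(C)[C@H]2CC[C@]1(C)N(Cc1cn(-c3ccccc3O)nn1)C(=O)C2`, which has 2-hydroxyphenyl in place of 4-bromophenyl on an aromatic nitrogen. The counted difference is 2-hydroxyphenyl in place of 4-bromophenyl on an aromatic nitrogen, and the shared core stays as it was.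

Within the data shown here, only one measured step bears on this change, since it too exchanges the group on that aromatic nitrogen. That step, a 2.8-fold higher number from compound 1 to compound 2 (0.44 log units; beyond the scatter), is modest. Among the measured compounds shown here, no compound bearing 2-hydroxyphenyl has been measured, so the data do not fix the direction. A step no larger than that one is expected in this assay, with a slight lean toward a lower number, as compound 1 stands at 40 nM on the same position. The expected step is a 1.2-fold lower number from compound 2 to compound 3 (0.09 log units; within the scatter) for now. Compound 3 is estimated at 90 nM, with an expected range from 25 nM to 320 nM as its bounds.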

Compound 3, half-maximal inhibitory concentration: 120 nM
The estimate for compound 3 lay 1.3-fold (0.12 log units) below the measured number; low and high end bracket the measured number.
By their numbers in this assay, from the lowest: compound 1; then compounds 2 and 3 (each within the scatter of the next).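

On the aromatic nitrogen, 2-hydroxyphenyl brings a hydrogen-bond donor and a hydrogen-bond acceptor that 4-bromophenyl does not have, yet in this assay the exchange amounts to a 1.1-fold higher number from compound 2 to compound 3 (0.04 log units; within the scatter) and does not separate the two groups. Set against 3-cyanophenyl, the same group gives a 3.0-fold higher number from compound 1 to compound 3 (0.48 log units; beyond the scatter), so compound 1 now stands apart from two differently substituted compounds and is the strongest inhibitor of the three, while compound 2 and compound 3 remain level within the scatter. Nothing in the available data accounts for how these groups compare at this position.

The three compounds leave open whether the standing of compound 1 belongs to the nitrile itself or to 3-cyanophenyl as a whole, since neither 4-cyanophenyl nor unsubstituted phenyl appears among them. They also leave open whether 3-hydroxyphenyl or 4-hydroxyphenyl would match compound 3, and how an aminophenyl or a carboxyphenyl group would fare on the same aromatic nitrogen.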